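Extending the amine on a urea kinase inhibitor core

The source may report more compounds than this note shows. Statements on the series, on what has been measured and on what is new or still open speak of the compounds shown alone.

Compound 1 `CCc1cc(NC(=O)Nc2cccc(C(F)(F)F)c2)cc(Cl)c1Oc1cc(NC)ncn1`: a limit of the assay, <= 10 nM in an assay on isolated protein for inhibition of serine/threonine-protein kinase TNNI3K (Homo sapiens); a higher number here means a weaker inhibitor, a lower number a stronger inhibitor.
Compound 2 `CNc1cc(Oc2ccc(NC(=O)Nc3cccc(C(F)(F)F)c3)c(F)c2F)ncn1`: 20 nM in this assay.
Compound 3 `O=C(Nc1ccc(Oc2ccncn2)cc1)Nc1cccc(C(F)(F)F)c1`: 160 nM in this assay.

Among the two plain numbers, compound 3 stands highest; its nearest neighbour, compound 2, sits at a lower number that lies beyond the usual scatter, while compound 1 is reported only as a limit. Compound 4 `CC(C)Nc1cc(Oc2ccc(NC(=O)Nc3cccc(C(F)(F)F)c3)cc2)ncn1` differs from compound 3 in one place: isopropylamino in place of hydrogen on an aromatic carbon. Both compound 1 and compound 2 carry a related amine on that part of the core and give the lower numbers, so the change is expected to strengthen inhibition by more than the scatter. In this assay compound 4 is expected to give 25 nM, within a range from 8 nM to 80 nM. This estimate means an expected step of a 6.4-fold lower number from compound 3 to compound 4 (0.81 log units; beyond the scatter).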

Compound 4, half-maximal inhibitory concentration: 40 nM
Beside the measured number, compound 4's estimate is 1.6-fold (0.20 log units) below it; the measured number falls inside the stated range.
By their numbers in this assay, from the lowest: compounds 2 and 4 (each within the scatter of the next); then compound 3. At a limit, below all of these: compound 1.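

Going by these compounds alone, compound 4 isolates this position for the first time: in this assay, isopropylamino in place of hydrogen, with nothing else changed, gives a 4.0-fold lower number from compound 3 to compound 4 (0.60 log units; beyond the scatter) and so a modest gain beyond the scatter. Compounds 1 and 2 carry a related amine but also differ elsewhere on the shared core, so they could not separate its effect. Nothing measured here gives a cause for this step.

On these data alone, whether an unsubstituted amine, a morpholine ring or a longer chain would serve this position differently stays open. Also unsettled is how much the other substituents on compounds 1 and 2 contribute.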